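A few compounds are considered here, and "the series" means these few. Any claim that something is new, unique, unknown or untested is made for them only; others in the source may bear on it.

Of the compounds shown here, three sharing one core have been measured in an assay on HeLa cells with Bile acid receptor (Homo sapiens) as the target, read by a luciferase reporter, with a stated time of 24 h; a higher number here means that more compound is needed for the effect, a lower number that less compound is needed. Compound 1 `CC(C)(C)c1ccc(C(=O)NCc2ccc(-c3nnn[nH]3)cc2)cc1` gives 120 nM in this assay, and compound 2 `CC(C)(C)c1ccc(C(=O)NCc2ccc(OC(F)(F)F)cc2)cc1` gives 160 nM in this assay, the two lying close: a 1.3-fold higher number from compound 1 to compound 2 (0.12 log units; within the scatter). Compound 3 `CC(=O)Nc1ccc(CNC(=O)c2ccc(C(C)(C)C)cc2)cc1` gives 2900 nM in this assay, the highest number of the three: a 24-fold higher number from compound 1 to compound 3 (1.38 log units; beyond the scatter), and an 18-fold higher number from compound 2 to compound 3 (1.26 log units; beyond the scatter).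

Compound 4 `CC(C)(C)c1ccc(C(=O)NCc2ccc(S(N)(=O)=O)cc2)cc1` differs from compound 3 in one place: sulfamoyl in place of acetamido on an aromatic carbon. Among the measured compounds shown here, no measured step changes acetamido into sulfamoyl, so the two large steps that put acetamido in place of another group at this carbon are the nearest guide; both show that leaving the acetamido behind can move the number by a wide margin, while nothing shows how far sulfamoyl goes. He therefore expects a lower number for compound 4 than for compound 3, a step of a 4.1-fold lower number from compound 3 to compound 4 (0.62 log units; beyond the scatter), though with wide uncertainty. His estimate for compound 4 in this assay is 700 nM, expected between 150 nM and 3000 nM.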

Compound 4, half-maximal effective concentration: 1400 nM
Compound 4: middle estimate off by 2.0-fold (0.30 log units), on the low side, and the stated range covers the measured number.
By their numbers in this assay, from the lowest: compounds 1 and 2 (each within the scatter of the next); then compound 4; then compound 3.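

Sulfamoyl and acetamido have the same count of heavy atoms, yet in this assay this first exchange between two groups that both sit at the weak end gives only a modest gain (a 2.1-fold lower number from compound 3 to compound 4 (0.32 log units; beyond the scatter)). Leaving the acetamido behind is therefore not enough on its own, since the sulfamoyl number remains well apart from those of the other two groups (an 8.8-fold higher number from compound 2 to compound 4 (0.94 log units; beyond the scatter) and a 12-fold higher number from compound 1 to compound 4 (1.07 log units; beyond the scatter)), and the position now shows an intermediate level rather than only a high and a low one. No measurement shown here accounts for this order among the groups.

From the compounds shown here alone, what remains open is where a carboxylic acid, an amine or a nitrile at this carbon would fall on that scale. Going by these compounds, it is also open whether methylsulfonyl, which lacks the nitrogen of sulfamoyl, would give a number near that of compound 4.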